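The source may report more compounds than this note shows. Statements on the series, on what has been measured and on what is new or still open speak of the compounds shown alone.

In an assay on cells for inhibition of MAP kinase-interacting serine/threonine-protein kinase 1 (Homo sapiens), read by mobility shift assay, with stated times of 10 min and 60 min, in the presence of a further agent that is not named here (on this read-out lower numbers stand for stronger inhibition and higher numbers for weaker inhibition), compound 1 `CC(C)Oc1cc(-c2cncc(-c3cnn(C4COC4)c3)c2)ccc1C(N)=O` gives 200 nM, compound 2 `Cc1[nH]ncc1-c1cncc(-c2ccc(C(N)=O)c(OC(C)C)c2)c1` gives 54 nM, and compound 3 `Cc1n[nH]c(C)c1-c1cncc(-c2ccc(C(N)=O)c(OC(C)C)c2)c1` gives 33 nM, the lowest of the three numbers. The step from compound 1 to compound 3 a 6.1-fold lower number from compound 1 to compound 3 (0.78 log units; beyond the scatter) lies beyond the scatter, whereas a 1.6-fold lower number from compound 2 to compound 3 (0.21 log units; within the scatter) stays within it. Compound 4 `Cc1c(-c2cncc(-c3ccc(C(N)=O)c(OC(C)C)c3)c2)cnn1C` differs from compound 3 in that (1,5-dimethyl-1H-pyrazol-4-yl in place of 3,5-dimethyl-1H-pyrazol-4-yl on an aromatic carbon). The measured steps of a 3.7-fold lower number from compound 1 to compound 2 (0.57 log units; beyond the scatter) and a 6.1-fold lower number from compound 1 to compound 3 (0.78 log units; beyond the scatter) bear on this change, as each replaces a pyrazole carrying a group on nitrogen by one with hydrogen there, the reverse of the present move. A modest rise in this assay is therefore expected for compound 4, a 3.0-fold higher number from compound 3 to compound 4 (0.48 log units; beyond the scatter), because a 6.1-fold lower number from compound 1 to compound 3 (0.78 log units; beyond the scatter) points the other way. Compound 4 is estimated at 100 nM, between 40 nM and 250 nM.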

Compound 4, half-maximal inhibitory concentration in the MAP kinase-interacting serine/threonine-protein kinase 1 assay: 60 nM
For compound 4 the middle estimate is 1.7-fold (0.22 log units) above the measured one; measured number inside the range.
By their numbers in the MAP kinase-interacting serine/threonine-protein kinase 1 assay, from the lowest: compounds 3, 2 and 4 (each within the scatter of the next); then compound 1.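

In the MAP kinase-interacting serine/threonine-protein kinase 1 assay compound 4 gives 60 nM, and the pyrazole need not keep a hydrogen on nitrogen at this position: a 1.8-fold higher number from compound 3 to compound 4 (0.26 log units; within the scatter) and a 1.1-fold higher number from compound 2 to compound 4 (0.05 log units; within the scatter). Yet a group on nitrogen does not by itself set the level, since compound 1 also carries one and a 3.3-fold lower number from compound 1 to compound 4 (0.52 log units; beyond the scatter), so the earlier steps cannot be read as a need for that hydrogen. In a physicochemical assay for solubility, measured as thermodynamic solubility, at pH 7.4 (a lower number here means a less soluble compound, a higher number a more soluble compound), compound 3 gives 10 ug/mL and compound 4 gives 7.3 ug/mL, which is a 1.4-fold lower number from compound 3 to compound 4 (0.14 log units; within the scatter). Nothing given here accounts for these results. Still open, on these data alone, is how a nitrogen substituent of another kind, such as an aminoethyl or a longer alkyl chain, would behave here.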